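A few compounds are considered here, and "the series" means these few. Any claim that something is new, unique, unknown or untested is made for them only; others in the source may bear on it.

Working notes on the series, all read in a toxicity assay on GES1 cells (Homo sapiens) for inhibition, read by MTT assay, with a stated time of 72 h; a lower number here means a stronger inhibitor, a higher number a weaker inhibitor. Compound 1 `Cc1cc(N2CC[C@@H](C)[C@@H](N(C)c3ncnc4[nH]ccc34)C2)n2nc(SCc3ccccc3Br)nc2n1` gives > 100000 nM, which is a limit and not a number. Compound 2 `Cc1cc(N2CC[C@@H](C)[C@@H](N(C)c3ncnc4[nH]ccc34)C2)n2nc(SCc3ccc(F)cc3)nc2n1` gives a true number, 12300 nM. Compound 3 `COc1ccc(CSc2nc3nc(C)cc(N4CC[C@@H](C)[C@@H](N(C)c5ncnc6[nH]ccc56)C4)n3n2)cc1` gives > 100000 nM, also only a limit. Compound 3 therefore stands at the limit of > 100000 nM in this assay, at which 2 of the 3 values shown sit.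

Compound 4 `CCCSc1nc2nc(C)cc(N3CC[C@@H](C)[C@@H](N(C)c4ncnc5[nH]ccc45)C3)n2n1` has ethyl in place of 4-methoxyphenyl on a saturated chain carbon bound to a sulfur, which amounts to (4-methoxybenzyl)sulfanyl to propylsulfanyl. The closest measured evidence comes from changes on the aromatic ring: an at least 8.1-fold lower number from compound 1 to compound 2 (0.91 log units; beyond the scatter), an at least 8.1-fold higher number from compound 2 to compound 3 (0.91 log units; beyond the scatter) and a step that the two limits leave unreadable from compound 1 to compound 3. Among the compounds with values here, no measured step removes that ring, so these steps guide the size only loosely. Compound 2 at 12300 nM shows that this series can give a true number, so a modest step to a lower number is expected. A result at the limit remains possible. The expected change is an at least 2.5-fold lower number from compound 3 to compound 4 (0.39 log units; beyond the scatter). The estimate for compound 4 is 40000 nM, with an expected range of 10000 nM to 100000 nM.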

Compound 4, half-maximal inhibitory concentration: 67100 nM
The estimate for compound 4 lay 1.7-fold (0.22 log units) below the measured number; low and high end bracket the measured number.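

In this assay, within the data shown here, compound 4 shows that a true number at this place, on a saturated chain carbon bound to a sulfur, does not depend on an aromatic ring, and compound 2 is no longer the only compound with one. Ethyl in place of 4-fluorophenyl gives a 5.5-fold higher number from compound 2 to compound 4 (0.74 log units; beyond the scatter), the first step here with a true number at both ends. The steps from the two limit compounds are only floors, an at least 1.4-fold lower number from compound 3 to compound 4 (0.17 log units; that floor lies within the scatter) and an at least 1.4-fold lower number from compound 1 to compound 4 (0.17 log units; that floor lies within the scatter), and neither floor clears the scatter: the limit of > 100000 nM in this assay, at which 2 of the 4 values shown sit.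

Open, going by these compounds, is whether a longer chain such as hexyl, or a propyl chain carrying an amine or a carboxylic acid, would move the number at this place. On these data alone, the step between compound 1 and compound 3 cannot be read, so the order of those two stays open.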